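Swapping a bromophenyl for a nitrophenyl at the triazole arm

This account rests on a few compounds, and the source may have more. Where it says the series, first, only, none or still open, it means among the compounds named here.

Three compounds share one core and differ only in the aromatic group hanging from the saturated chain carbon bound to an aromatic nitrogen. Compound 1 `Cc1ccc(Cn2cc(COc3ccc4c(=O)ccoc4c3)nn2)cc1` is tested in a functional assay on A549 cells (Homo sapiens) for cytotoxicity, read by MTT assay, with a stated time of 48 h (a lower number here means a stronger inhibitor, a higher number a weaker inhibitor), and gives 50700 nM. Compound 2 `O=c1ccoc2cc(OCc3cn(Cc4cccc(Br)c4)nn3)ccc12` gives in this assay only a limit of the assay and not a number, > 100000 nM. Compound 3 `CC(C)(C)c1ccc(Cn2cc(COc3ccc4c(=O)ccoc4c3)nn2)cc1` likewise gives in this assay a limit and not a number, > 100000 nM. The two measured steps are an at least 1.9-fold higher number from compound 1 to compound 2 (0.29 log units; that floor lies within the scatter) and an at least 1.9-fold higher number from compound 1 to compound 3 (0.29 log units; that floor lies within the scatter), and both end at the limit of > 100000 nM in this assay, at which 2 of the 3 values shown sit, so compound 2 stands at the weak end of what the assay can report.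

Compound 4 `O=c1ccoc2cc(OCc3cn(Cc4ccc([N+](=O)[O-])cc4)nn3)ccc12` has not yet been measured. It differs from compound 2 by 4-nitrophenyl in place of 3-bromophenyl on a saturated chain carbon bound to an aromatic nitrogen. Going by the values given here, no measured step changes this group in a comparable way, and both changes to compound 1 led only to the limit. The expected step of a number no higher from compound 2 to compound 4 (the limit leaves the size open) is therefore none beyond the scatter, with compound 4 expected near the limit in this assay. Compound 4 is estimated at 100000 nM, within 40000 nM to 250000 nM.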

Compound 4, half-maximal inhibitory concentration: > 100000 nM
Compound 4 gave a limit, no number; the forecaster's own chance of this, stated with the estimate: 60%; the middle value sits exactly at the limit.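

Three different aromatic groups at this position, 3-bromophenyl, the tert-butyl-bearing phenyl of compound 3 and now 4-nitrophenyl, all leave the compound without a number in this assay, and only compound 1 goes against this pattern. Going by these compounds alone, the one readable step is an at least 1.9-fold higher number from compound 1 to compound 4 (0.29 log units; that floor lies within the scatter), so nitro in place of methyl on an aromatic carbon shows no change that can be told from the scatter. The steps joining compound 4 to compound 2 and to compound 3 cannot be read, because both ends of each sit at the same limit: the limit of > 100000 nM in this assay, at which 3 of the 4 values shown sit.

As far as these compounds go, it remains open how far compound 2, compound 3 and compound 4 lie past that limit. From the compounds shown here alone, it also remains open whether an amine or a carboxylic acid in place of the methyl would improve on compound 1, at 50700 nM.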